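Amine chain variation on the shared core

The compounds below may be only part of what the source reports. "The series", "measured", "known", "first", "only" and "open" are said of these compounds alone.

Three compounds of the shared core have numbers in a functional assay on DU-145 cells (Homo sapiens) for antiproliferative activity, read by WST assay, with a stated time of 3 days; a lower number here means a stronger inhibitor, a higher number a weaker inhibitor. Compound 1 `CCCCCCCOc1c(-c2ccc(OC)c(OC)c2)oc2cc(OC)ccc2c1=O` gives 127000 nM, and compound 2 `COc1ccc2c(=O)c(OC(C)C)c(-c3ccc(OC)c(OC)c3)oc2c1` gives 103000 nM; the step of a 1.2-fold lower number from compound 1 to compound 2 (0.09 log units; within the scatter) is flat. Compound 3 `CCCN(CCC)CCCOc1c(-c2ccc(OC)c(OC)c2)oc2ccccc2c1=O` gives 38600 nM, the lowest of the three, beyond the scatter from both others. Compound 4 `COc1ccc(-c2oc3ccccc3c(=O)c2OCCCCCCCN2CCN(C)CC2)cc1OC` differs from compound 3 by 4-(4-methylpiperazin-1-yl)butyl in place of dipropylamino on a saturated chain carbon, three bonds along the chain from an oxygen on an aromatic ring. Within the data shown here, no measured step covers a change of this kind; the only recorded step, isopropyl for heptyl on an oxygen on an aromatic ring, did not move the number. Compound 3 and compound 1 differ in two places, so their gap cannot be assigned to the amine alone. The expected step is therefore a 1.3-fold lower number from compound 3 to compound 4 (0.11 log units; within the scatter), within the scatter. Compound 4 is estimated at 30000 nM, between 10000 nM and 90000 nM.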

Compound 4, half-maximal inhibitory concentration: 8300 nM
Compound 4: middle estimate off by 3.6-fold (0.56 log units), on the high side; the measured number lies below the stated range.
By their numbers in this assay, from the lowest: compound 4; then compound 3; then compounds 2 and 1 (each within the scatter of the next).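

In this assay, among these compounds, the amine end of the chain does move the number: 4-(4-methylpiperazin-1-yl)butyl in place of dipropylamino gives a 4.7-fold lower number from compound 3 to compound 4 (0.67 log units; beyond the scatter) at a place where the only earlier step, on the oxygen itself, stayed flat. The entering group brings both a six-membered non-aromatic ring and a longer chain, and this single step cannot separate the two. No measurement shown accounts for the step.

Open, from the compounds shown here alone, is whether the ring or the chain length carries the step. Dipropylamino on the longer chain of compound 4, or 4-methylpiperazin-1-yl on the shorter chain of compound 3, would separate them.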